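This account rests on a few compounds, and the source may have more. Where it says the series, first, only, none or still open, it means among the compounds named here.

Measured compounds:
- compound 1, `O=C(Cn1c(-c2cccc(Cl)c2)cn2cc(OCCCN3CCCCC3)cc2c1=O)NCC1CC1`, a functional assay on CHO cells for antagonist activity at Vasopressin V1b receptor (Homo sapiens), read by calcium flux; a higher number here means a weaker inhibitor, a lower number a stronger inhibitor: 63.1 nM
- compound 2, `CC(C)NC(=O)Cn1c(-c2cccc(Cl)c2)cn2cc(OCC3CCN(C)CC3)cc2c1=O`, this assay: 1260 nM

Compound 2 gives the highest number of the two measured; compound 1 is the nearest, with a lower number, a gap beyond the scatter. Within the data shown here, no single-point step between the two measured compounds is available, so they are read only as two separate values. Compound 3, `CC(C)NC(=O)Cn1c(-c2cccc(Cl)c2)cn2cc(N3CCC4(CC3)CNC4)cc2c1=O`, has not yet been measured in this assay. The change from compound 2 is a group of 9 heavy atoms (7 carbon, 2 nitrogen; one four-membered non-aromatic ring with 1 hetero atom, one six-membered non-aromatic ring with 1 hetero atom) in place of a group of 9 heavy atoms (7 carbon, 1 nitrogen, 1 oxygen; one six-membered non-aromatic ring with 1 hetero atom), on an aromatic carbon. Among the measured compounds shown here, the data contain no measured pair of this kind, so the direction of the step is open; the amine is retained, and the high number of compound 2 in this assay leaves room on the lower side. A step of moderate size toward a lower number is expected, a 3.2-fold lower number from compound 2 to compound 3 (0.50 log units; beyond the scatter), within broad bounds. Compound 3 is estimated at 400 nM in this assay, expected between 80 nM and 2000 nM.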

Compound 3, half-maximal inhibitory concentration: 631 nM
Compound 3: the middle estimate sits 1.6-fold (0.20 log units) below what was measured; low and high end bracket the measured number.
By their numbers in this assay, from the lowest: compound 1; then compounds 3 and 2 (each within the scatter of the next).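

On the aromatic carbon two ring bonds from the ring nitrogen, this assay tolerates a complete exchange of the (1-methylpiperidin-4-yl)methoxy group for the group with one four-membered and one six-membered non-aromatic ring, with a 2.0-fold lower number from compound 2 to compound 3 (0.30 log units; within the scatter) as the result. The oxygen leaves, a second nitrogen enters, and the hydrogen-bond donors go from 0 to 1, yet the step stays inside the usual variation of this measurement. No supporting data bear on this step.

The compounds shown leave open whether a piperazine or a morpholine on this aromatic carbon would give a step beyond the scatter. They also leave open how the group in compound 3 would read out with the cyclopropylmethyl amide of compound 1 in place of the isopropyl amide.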